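Aryl variation on the shared core: bromo to fluoro

The compounds below may be only part of what the source reports. "The series", "measured", "known", "first", "only" and "open" are said of these compounds alone.

Measured compounds:
- compound 1, `CC(=O)c1ccc(-c2cn3ccnc3c(-c3ccc4ncn(C5CCCCC5)c4c3)n2)cc1`, 0.73% in a functional assay on MDA-MB-468 cells (Homo sapiens) for inhibition, read by sulforhodamine B assay, with a stated time of 48 h, tested at 10 uM; on this read-out lower numbers stand for less inhibition and higher numbers for more inhibition at the one concentration tested (going by the name of the read-out)
- compound 2, `Brc1ccc(-c2cn3ccnc3c(-c3ccc4ncn(C5CCCCC5)c4c3)n2)cc1`, 33.7% in this assay

For the measured compounds named here, compound 2 gives the higher of the two numbers so far, with compound 1 the only neighbour, and the sole step between measured compounds is a number 33 percentage points higher from compound 1 to compound 2 (beyond the scatter). Compound 3, `Fc1ccccc1-c1cn2ccnc2c(-c2ccc3ncn(C4CCCCC4)c3c2)n1`, is not yet measured; it differs from compound 2 as follows: 2-fluorophenyl in place of 4-bromophenyl on an aromatic carbon. Going by the values given here, no measured step swaps one halogenated phenyl for another, so the acetyl-to-bromo step from compound 1 to compound 2 bears on it only loosely, showing that this position on the core does move the read-out by a large amount. Among the compounds with values here, with no closer precedent, compound 3 is expected to land below compound 2, a step of a number 13.7 percentage points lower from compound 2 to compound 3 (beyond the scatter), with wide uncertainty. The estimate for compound 3 in this assay is 20%, within 0% to 45%.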

Compound 3, a percentage reported as inhibition, at one concentration (the size of the read-out at that concentration, not a potency): 27.6%
Compound 3: the middle estimate sits 7.6 percentage points below what was measured; low and high end bracket the measured number.
By their numbers in this assay, from the lowest: compound 1; then compounds 3 and 2 (each within the scatter of the next).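

In this assay, replacing 4-bromophenyl with 2-fluorophenyl gives a number 6.1 percentage points lower from compound 2 to compound 3 (within the scatter), so a second halogen-bearing phenyl group now sits alongside the first, and this change does not separate the two. Against the acetyl-bearing compound, 2-fluorophenyl in place of 4-acetylphenyl gives a number 26.9 percentage points higher from compound 1 to compound 3 (beyond the scatter), which shows that the large gain seen with bromo is not unique to that group, and that compound 1 stands apart from both halogen-bearing compounds. Nothing on hand accounts for either step.

The halogen and its place on the phenyl change together here, so the contribution of each cannot be told apart. As far as these compounds go, how the unsubstituted phenyl, or a phenyl carrying an amine or a carboxylic acid, would read at this position remains open.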